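Compound 3: an expected step to a higher number

The source may hold more compounds than are shown below. What is called first, only, known or untested is meant among the compounds shown, and "the series" means these compounds.

In a functional assay, with a stated time of 30 min, in the absence of a further agent (on this read-out higher numbers stand for weaker inhibition and lower numbers for stronger inhibition), compound 1 (`O=C(/C=C/c1ccc(O)cc1)OCCOc1no[n+]([O-])c1S(=O)(=O)c1ccccc1`) gives 1390000 nM and compound 2 (`COc1cc(/C=C/C(=O)OCCOc2no[n+]([O-])c2S(=O)(=O)c2ccccc2)ccc1O`) gives 181000 nM as the lower of the two numbers, so compound 2 is the stronger inhibitor of this pair. Among the measured compounds shown here, the only measured step, a 7.7-fold lower number from compound 1 to compound 2 (0.89 log units; beyond the scatter) for methoxy in place of hydrogen on an aromatic carbon, is modest but beyond the scatter. Compound 3 (`O=C(/C=C/c1ccccc1)OCCOc1no[n+]([O-])c1S(=O)(=O)c1ccccc1`) has not yet been measured. Its difference from compound 2 is phenyl in place of 4-hydroxy-3-methoxyphenyl on a double-bonded chain carbon bound to a double-bonded chain carbon and nothing else. This removes the methoxy group of that step together with the hydroxy group that compound 1 and compound 2 both carry. For the measured compounds named here, no measured compound shows what losing the hydroxy group does. Going by a 7.7-fold lower number from compound 1 to compound 2 (0.89 log units; beyond the scatter) read in reverse, a move to a higher number is expected in this assay from the methoxy loss alone, and the hydroxy loss leaves the size open. The expected change is a 5.5-fold higher number from compound 2 to compound 3 (0.74 log units; beyond the scatter) in size, about as large as the measured step, with wide uncertainty. Compound 3 is estimated at 1000000 nM within a range of 200000 nM to 5000000 nM as the expected outcome.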

Compound 3, half-maximal inhibitory concentration: > 10000000 nM
Compound 3: a limit, no number (the forecaster's own chance of this, stated with the estimate: 30%); middle value at least 10-fold (1.00 log units) from the limit.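

In this assay, the reading for compound 3 is a limit of the assay and not a number: the limit of > 10000000 nM in this assay, at which 1 of the 3 values shown sits. Hydrogen in place of hydroxy on an aromatic carbon gives an at least 7.1-fold higher number from compound 1 to compound 3 (0.85 log units; beyond the scatter), so the hydroxy group, which both earlier compounds carried and no earlier step changed, now has a measured part in inhibition here, and its loss alone is enough to reach the limit. Taking away the methoxy group as well, with phenyl in place of 4-hydroxy-3-methoxyphenyl on a double-bonded chain carbon bound to a double-bonded chain carbon, gives an at least 55-fold higher number from compound 2 to compound 3 (1.74 log units; beyond the scatter), a large step that sets the whole substituted ring against the bare one, though only as a lower bound on its size.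

The compounds shown leave open how large either step really is, and whether the methoxy group would lower the number without the hydroxy group present. They also do not tell whether an amine or a carboxylic acid could stand in for the hydroxy group, or how a longer chain in the ester link would change the reading.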